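Ethyl-to-methyl exchange on the piperazine of a quinazoline series

The compounds below may be only part of what the source reports. "The series", "measured", "known", "first", "only" and "open" are said of these compounds alone.

Measured compounds:
- compound 1 `CCN1CCN(c2nc(C)c3cc(NC(=O)COc4ccc(Cl)cc4)ccc3n2)CC1`: "not determined" (no result reported)
- compound 2 `Cc1nc(N2CCN(C(=O)C3CC3)CC2)nc2ccc(NC(=O)COc3ccc(OC(F)(F)F)cc3)cc12`: 30 nM

Compound 1 stands on no number here; only compound 2 carries a result. In a functional assay on CHO-K1 cells for antagonist activity at melanin-concentrating hormone receptor 1 (Homo sapiens), read by inositol phosphate accumulation (on this read-out lower numbers stand for stronger inhibition and higher numbers for weaker inhibition), compound 2 gives 30 nM. Compound 3 `Cc1nc(N2CCN(C)CC2)nc2ccc(NC(=O)COc3ccc(Cl)cc3)cc12` differs from compound 1 by hydrogen in place of methyl on a saturated chain carbon bound to an amine nitrogen in a ring. No direct comparison is measured for this change, and its size in this assay cannot be read from the series; a step no larger than the scatter, in either direction, seems likeliest. On that basis, and with compound 2 at 30 nM as the only anchor, compound 3 is expected at 40 nM, between 10 nM and 160 nM.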

Compound 3, half-maximal inhibitory concentration: 3800 nM
Compound 3: middle estimate off by 95-fold (1.98 log units), on the low side; the whole stated range lies below it.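

Within the data shown here, with no number for compound 1, no step to compound 3 can be read, and compound 2 differs from compound 3 in more than one place. The compounds shown leave open what the ethyl-to-methyl exchange alone does to inhibition. No evidence bears on the result for compound 3.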